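Compound 3 to compound 4: bromo in place of chloro

The source may hold more compounds than are shown below. What is called first, only, known or untested is meant among the compounds shown, and "the series" means these compounds.

In a functional assay on A549 cells (Homo sapiens) for cytotoxicity, read by MTT assay, with a stated time of 72 h (on this read-out lower numbers stand for stronger inhibition and higher numbers for weaker inhibition), compound 1 `COc1cccc(/C=C2\CCC/C(=C\c3cccc(Cl)c3Cl)C2=O)c1OC` gives > 20000 nM, a limit and not a number. Compound 2 `COc1ccc(/C=C2\CCC/C(=C\c3ccccc3Cl)C2=O)cc1OC` gives > 20000 nM, also a limit. For the measured compounds named here, compound 3 `COc1ccc(/C=C2\CCC/C(=C\c3ccc(Cl)cc3)C2=O)cc1OC` gives 10100 nM, the only true number in the set. Going by the values given here, the one measured step is an at least 1.9-fold lower number from compound 2 to compound 3 (0.29 log units; that floor lies within the scatter). That step alters where the chlorine sits, not which halogen is present, so it bears only loosely on the next change. Compound 4 `COc1ccc(/C=C2\CCC/C(=C\c3ccc(Br)cc3)C2=O)cc1OC` differs from compound 3 by bromo in place of chloro on an aromatic carbon. Among the compounds with values here, no measured step covers this exchange, so no shift beyond the scatter is expected. The estimated step is a 1.1-fold lower number from compound 3 to compound 4 (0.05 log units; within the scatter). Compound 4 is expected at 9000 nM, with an estimated range of 4500 nM to 18000 nM.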

Compound 4, half-maximal inhibitory concentration: 16000 nM
Compound 4: middle estimate off by 1.8-fold (0.25 log units), on the low side; the range from low to high includes it.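

In this assay the exchange gives a 1.6-fold higher number from compound 3 to compound 4 (0.20 log units; within the scatter) and so leaves bromo and chloro, on an aromatic carbon para to a large group, not told apart. Only a floor can be read for an at least 1.2-fold lower number from compound 2 to compound 4 (0.09 log units; that floor lies within the scatter) and it gives no separation between the 4-bromophenyl and 2-chlorophenyl compounds: the limit of > 20000 nM in this assay, at which 2 of the 4 values shown sit.

Still open, as far as these compounds go, is whether any other group at this place moves the number beyond the scatter. An amine or a carboxylic acid in place of the halogen would test this.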